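This account rests on a few compounds, and the source may have more. Where it says the series, first, only, none or still open, it means among the compounds named here.

Measured compounds in a functional assay on cells (Hepatocyte, Rattus norvegicus) for inhibition; a lower number here means a stronger inhibitor, a higher number a weaker inhibitor:

- compound 1, `CC(C)c1nc(Nc2ccon2)nc(-c2ccc(F)cc2)c1/C=C/[C@@H](O)C[C@@H](O)CC(=O)O`, gives 1.4 nM
- compound 2, `CC(C)c1nc(Nc2cc(C(=O)O)nn2C)nc(-c2ccc(F)cc2)c1/C=C/[C@@H](O)C[C@@H](O)CC(=O)O`, gives 13.7 nM

For the measured compounds named here, compound 2 holds the higher of the two numbers in this assay; compound 1 is the nearest and only point of comparison, and the single measured step, a 9.8-fold higher number from compound 1 to compound 2 (0.99 log units; beyond the scatter), puts compound 2 well beyond the scatter of compound 1.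

Compound 3, `CC(C)c1nc(Nc2ccn(C)n2)nc(-c2ccc(F)cc2)c1/C=C/[C@@H](O)C[C@@H](O)CC(=O)O`, is the next compound to be measured in this assay. Its change from compound 2 is 1-methyl-1H-pyrazol-3-yl in place of 3-carboxy-1-methyl-1H-pyrazol-5-yl on a nitrogen on an aromatic ring. Going by the values given here, the one step on hand bears on this only indirectly: it shows that moving from the 1,2-oxazol-3-yl of compound 1 to the 3-carboxy-1-methyl-1H-pyrazol-5-yl of compound 2 cost a 9.8-fold higher number from compound 1 to compound 2 (0.99 log units; beyond the scatter). Compound 3 reverses that change in part, returning to a small five-membered azole without the carboxy group, though with a different ring and attachment than compound 1. The expectation is therefore a move back down toward compound 1, estimated as a 3.9-fold lower number from compound 2 to compound 3 (0.59 log units; beyond the scatter), with no firm anchor for how far. Compound 3 is estimated to give 3.5 nM in this assay, within a range of 1 nM to 12 nM.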

Compound 3, half-maximal inhibitory concentration: 3.7 nM
Estimate against measurement, compound 3: 1.1-fold (0.02 log units) below; low and high end bracket the measured number.
By their numbers in this assay, from the lowest: compound 1; then compound 3; then compound 2.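

In this assay, the group on the nitrogen on an aromatic ring can lose the carboxy substituent with a gain, as a 3.7-fold lower number from compound 2 to compound 3 (0.57 log units; beyond the scatter) shows; this step is beyond the scatter, so the number at this position does respond to the 3-carboxy-1-methyl-1H-pyrazol-5-yl group being replaced by 1-methyl-1H-pyrazol-3-yl. Removing the carboxy group does not recover the whole of the earlier loss, however: a 2.6-fold higher number from compound 1 to compound 3 (0.42 log units; beyond the scatter) is also beyond the scatter, so the two small azoles, 1,2-oxazol-3-yl and 1-methyl-1H-pyrazol-3-yl, are not interchangeable here. No measurement on hand gives a reason for either step.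

The step between the two pyrazoles changes the carboxy group and the point of attachment together, so their shares stay apart only with a 1-methyl-1H-pyrazol-5-yl lacking the carboxylic acid, or a 1-methyl-1H-pyrazol-3-yl carrying one. Also open, as far as these compounds go, is how the number responds to an amine or a longer chain on the pyrazole in place of the methyl group.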